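The source may hold more compounds than are shown below. What is called first, only, known or untested is meant among the compounds shown, and "the series" means these compounds.

Working notes on the series, read in a functional assay on Raji cells (Homo sapiens) for cytotoxicity, read by CCK-8 assay, with a stated time of 24 h; on this read-out lower numbers stand for stronger inhibition and higher numbers for weaker inhibition. Compound 1 (`C=CC(=O)N1C(=O)CC(C)Sc2ccccc21`) gives 837000 nM, compound 2 (`C=CC(=O)N1C(=O)CC(c2ccc(Cl)cc2)Sc2ccccc21`) gives 18400 nM and compound 3 (`C=CC(=O)N1C(=O)CC(c2cccs2)Sc2ccccc21`) gives 659000 nM. Two steps place the thiophen-2-yl member: a 1.3-fold lower number from compound 1 to compound 3 (0.10 log units; within the scatter), and a 36-fold higher number from compound 2 to compound 3 (1.55 log units; beyond the scatter). Compound 4 (`C=CC(=O)N1C(=O)CC(c2ccccc2)Sc2ccccc21`) has phenyl in place of thiophen-2-yl on a saturated ring carbon. The nearest guide is the 4-chlorophenyl step, a 45-fold lower number from compound 1 to compound 2 (1.66 log units; beyond the scatter), but compound 4 carries no chloro group, so only part of that step is expected to carry over. A clear but smaller step towards lower numbers in this assay is expected, estimated as a 5.5-fold lower number from compound 3 to compound 4 (0.74 log units; beyond the scatter). The estimate for compound 4 is 120000 nM, with an expected range of 30000 nM to 450000 nM.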

Compound 4, half-maximal inhibitory concentration: 74100 nM
The estimate for compound 4 lay 1.6-fold (0.21 log units) above the measured number, within the range that was stated.
By their numbers in this assay, from the lowest: compound 2; then compound 4; then compounds 3 and 1 (each within the scatter of the next).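

On the saturated ring carbon next to the ring sulfur, an 8.9-fold lower number from compound 3 to compound 4 (0.95 log units; beyond the scatter) and an 11-fold lower number from compound 1 to compound 4 (1.05 log units; beyond the scatter) in this assay show that phenyl separates from both thiophen-2-yl and methyl, which lie within the scatter of each other. The chloro group also counts, with a 4.0-fold higher number from compound 2 to compound 4 (0.61 log units; beyond the scatter) on its removal, so the low number of compound 2 rests on both the phenyl ring and the chloro group. Nothing available explains these steps.

Still open, from the compounds shown here alone, is whether the chloro group's step depends on where it sits on the phenyl ring, and what a methoxy group or an amine would do in its place.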